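A few compounds are considered here, and "the series" means these few. Any claim that something is new, unique, unknown or untested is made for them only; others in the source may bear on it.

The series shares one core, seen in compound 1 `Cc1cc(Nc2cc(-c3ccccc3)[nH]n2)n2nc(SCc3ccc(Cl)cc3)nc2n1`, and was tested in a functional assay on PC-9 cells (Homo sapiens) for inhibition, read by MTT assay, with a stated time of 72 h (a lower number here means a stronger inhibitor, a higher number a weaker inhibitor), where compound 1 gives 6710 nM. Compound 2 `Cc1cc(Nc2cc(-c3ccccc3)[nH]n2)n2nc(SCCc3ccccc3)nc2n1` differs from it only on the chain bound to the sulfur, and in this assay compound 2 gives 4930 nM; the step of a 1.4-fold lower number from compound 1 to compound 2 (0.13 log units; within the scatter) is within the scatter, so the two sit together and neither can be called the more potent. Compound 3 `Cc1nc2nc(SCc3ccc(Cl)cc3)nn2c(Nc2cc(-c3ccccc3)[nH]n2)c1C` carries a methyl on an aromatic carbon of the core, and in this assay compound 3 reaches only the limit > 50000 nM, a limit rather than a number (the limit of > 50000 nM in this assay, at which 1 of the 3 values shown sits); the step of an at least 7.4-fold higher number from compound 1 to compound 3 (0.87 log units; beyond the scatter) is beyond the scatter.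

Compound 4 `C#CCSc1nc2nc(C)cc(Nc3cc(-c4ccccc4)[nH]n3)n2n1` is not yet measured. The change from compound 2 is ethynyl in place of benzyl on a saturated chain carbon bound to a sulfur. Among the compounds with values here, only the step from compound 1 to compound 2 touches the same place, and it stayed within the scatter, although that exchange kept a ring while this one removes it. Compound 4 is therefore expected to give about 7000 nM, between 2500 nM and 25000 nM. The step of a 1.4-fold higher number from compound 2 to compound 4 (0.15 log units; within the scatter) is expected to stay near the scatter, with a slight lean toward a higher number.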

Compound 4, half-maximal inhibitory concentration: > 50000 nM
Compound 4: a limit, no number (the forecaster's own chance of this, stated with the estimate: 10%); middle value at least 7.1-fold (0.85 log units) away from the limit.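

In this assay, the chain bound to the sulfur turns out not to be freely exchangeable: the exchange between compound 1 and compound 2 kept a ring and stayed within the scatter, whereas an at least 10-fold higher number from compound 2 to compound 4 (1.00 log units; beyond the scatter) and an at least 7.4-fold higher number from compound 1 to compound 4 (0.87 log units; beyond the scatter) both lie beyond it. Compound 4 stands at a limit, not a number, so these steps fix only a minimum size for the change: the limit of > 50000 nM in this assay, at which 2 of the 4 values shown sit. Among the compounds shown, the ring-bearing chains give measurable values and the ring-free propargyl chain does not, although the removal of the ring cannot be told apart from the smaller size of the group.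

A saturated butyl chain or a cyclohexyl ring on the sulfur would separate these two readings. The compounds shown also leave open how an amine or a carboxylic acid on this chain would behave.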